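The source may hold more compounds than are shown below. What is called first, only, known or untested is meant among the compounds shown, and "the series" means these compounds.

Working notes on the series.

Compound 1 `OCCc1cn(CCNc2nonc2/C(=N/O)Nc2ccc(F)c(Br)c2)nn1` gives 247 nM in an assay on isolated protein for inhibition of Indoleamine 2,3-dioxygenase 1 (Homo sapiens); a lower number here means a stronger inhibitor, a higher number a weaker inhibitor. For the measured compounds named here, compound 2 `CC(C)(O)c1cn(CCNc2nonc2/C(=N/O)Nc2ccc(F)c(Br)c2)nn1` gives 115 nM in the same assay, and the one change between them, a 2.1-fold lower number from compound 1 to compound 2 (0.33 log units; beyond the scatter), is the only step measured so far. On these two numbers compound 2 stands lowest, with compound 1 the nearer and only neighbour.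

Compound 3 `CC(C)(OCCO)c1cn(CCNc2nonc2/C(=N/O)Nc2ccc(F)c(Br)c2)nn1` differs from compound 2 by 2-hydroxyethyl in place of hydrogen on an oxygen on a saturated carbon. Going by the values given here, no measured step covers an addition on this oxygen; the only step that touches the same region of the molecule is the one from compound 1 to compound 2, which was modest and concerned the carbon bearing the hydroxy rather than the hydroxy itself. On that basis the step to compound 3 is expected to stay small, and compound 3 is estimated at 140 nM in this assay, within 55 nM to 360 nM, meaning an expected step of a 1.2-fold higher number from compound 2 to compound 3 (0.09 log units; within the scatter).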

Compound 3, half-maximal inhibitory concentration: 176 nM
For compound 3 the middle estimate is 1.3-fold (0.10 log units) below the measured one; measured number inside the range.
By their numbers in this assay, from the lowest: compounds 2, 3 and 1 (each within the scatter of the next, the first and the last beyond it).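

For the compounds shown here, the addition of 2-hydroxyethyl on this oxygen is the first change measured at the hydroxy itself, and in this assay it gives a 1.5-fold higher number from compound 2 to compound 3 (0.18 log units; within the scatter). Set against the 2-hydroxyethyl group on the aromatic carbon, 1-(2-hydroxyethoxy)-1-methylethyl gives a 1.4-fold lower number from compound 1 to compound 3 (0.15 log units; within the scatter), so compound 3 cannot be told apart from either neighbour, even though compound 1 and compound 2 differ beyond the scatter. No evidence at hand bears on what lies behind these steps.

The compounds shown leave open whether the free hydroxy of compound 2 matters at all, since only one group on this oxygen is covered. A methoxy in place of that hydroxy, or an amine or a carboxylic acid in place of the hydroxy of the 2-hydroxyethyl group, would test this, as would a longer chain on the oxygen.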